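Methoxy-trifluoromethyl anilines on a trifluoromethylpyrimidine core

The source may report more compounds than this note shows. Statements on the series, on what has been measured and on what is new or still open speak of the compounds shown alone.

Measured compounds:
compound 1, `CN(c1cccc2c1CN(c1nc(Nc3cc(C(F)(F)F)cc(C(F)(F)F)c3)ncc1C(F)(F)F)C2)S(C)(=O)=O`, 9200 nM
compound 2, `CN(c1cccc2c1CN(c1nc(Nc3cc(Cl)cc(C(F)(F)F)c3)ncc1C(F)(F)F)C2)S(C)(=O)=O`, 4300 nM
compound 3, `Cc1ccc(Nc2ncc(C(F)(F)F)c(N3Cc4cccc(N(C)S(C)(=O)=O)c4C3)n2)cc1C`, a limit only

All three share one core and differ only in the aryl group on the aromatic nitrogen. In a functional assay on HeLa cells (Homo sapiens) for antiproliferative activity, read by spectrophotometry, with a stated time of 2 days (a lower number here means a stronger inhibitor of growth, a higher number a weaker inhibitor of growth), compound 3 reaches only the limit > 30000 nM, which is the limit of > 30000 nM in this assay, at which 1 of the 3 values shown sits. Compound 3 therefore stands at the weak end of the numbers shown. Compound 4, `COc1cc(Nc2ncc(C(F)(F)F)c(N3Cc4cccc(N(C)S(C)(=O)=O)c4C3)n2)cc(C(F)(F)F)c1`, has not been measured; it differs by 3-methoxy-5-(trifluoromethyl)phenyl in place of 3,4-dimethylphenyl on a nitrogen on an aromatic ring. Among the compounds with values here, two steps bear on this. From compound 2 to compound 3 the number rose by an at least 6.9-fold higher number from compound 2 to compound 3 (0.84 log units; beyond the scatter); from compound 1 to compound 2 it fell by a 2.1-fold lower number from compound 1 to compound 2 (0.33 log units; beyond the scatter). Since compound 4 returns a trifluoromethyl-bearing aryl like compounds 1 and 2, a drop beyond the scatter is expected, an at least 3.7-fold lower number from compound 3 to compound 4 (0.57 log units; beyond the scatter). Compound 4 is estimated at 8000 nM, between 3000 nM and 25000 nM.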

Compound 4, concentration for 50% growth inhibition: 5100 nM
Estimate against measurement, compound 4: 1.6-fold (0.20 log units) above, within the range that was stated.
By their numbers in this assay, from the lowest: compounds 2, 4 and 1 (each within the scatter of the next, the first and the last beyond it). At a limit, above all of these: compound 3.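

In this assay the 3-methoxy-5-(trifluoromethyl)phenyl group on the nitrogen gives an at least 5.8-fold lower number from compound 3 to compound 4 (0.76 log units; beyond the scatter), a real gain over 3,4-dimethylphenyl. Compound 3 stands at a limit: the limit of > 30000 nM in this assay, at which 1 of the 4 values shown sits. Methoxy on the aromatic carbon gives a 1.2-fold higher number from compound 2 to compound 4 (0.07 log units; within the scatter) and also a 1.8-fold lower number from compound 1 to compound 4 (0.26 log units; within the scatter), so compound 4 cannot be told apart from either compound 2 or compound 1.

The compounds shown do not separate the part played by the methoxy from that of the trifluoromethyl. As far as these compounds go, it also stays open how an amine or a carboxylic acid on the aryl ring would fare.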